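The source may report more compounds than this note shows. Statements on the series, on what has been measured and on what is new or still open speak of the compounds shown alone.

For the measured compounds named here, in a functional assay on U-937 cells (Homo sapiens) for cytotoxicity, read by MTT assay, with a stated time of 24 h (a higher number here means a weaker inhibitor, a lower number a stronger inhibitor), compound 1 `CCCCCCCCCCn1cc(-c2nc3ccccc3cc2CCCC)nn1` gives 25.2 ug/mL, the only exact number available so far. Compound 2 `CCCCCc1cc2ccccc2nc1-c1cn(CCC(F)(F)C(F)(F)C(F)(F)C(F)(F)C(F)(F)C(F)(F)C(F)(F)C(F)(F)F)nn1` is reported only as a limit of the assay, > 100 ug/mL, and not as a number. Compound 3 `CCCCCCCCCCn1cc(-c2nc3ccccc3cc2CCCCC)nn1` is compound 1 with one small edit: methyl in place of hydrogen on a saturated chain carbon, four bonds along the chain from an aromatic carbon. In words, a methyl stands in place of a hydrogen on a saturated chain carbon, four bonds along the chain from an aromatic carbon. Going by the values given here, no pair of measured compounds shows this change on its own, so the expectation has to start from compound 1 at 25.2 ug/mL. In this assay, no step beyond the usual scatter is expected, and neither direction is favoured. The estimated step of a 1.1-fold higher number from compound 1 to compound 3 (0.05 log units; within the scatter) stays within that scatter. Compound 3 is expected at 28 ug/mL, with an estimated range of 12 ug/mL to 60 ug/mL.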

Compound 3, half-maximal inhibitory concentration: 18.2 ug/mL
Compound 3: middle estimate off by 1.5-fold (0.19 log units), on the high side; low and high end bracket the measured number.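

In this assay, a methyl in place of a hydrogen on a saturated chain carbon, four bonds along the chain from an aromatic carbon, gives a 1.4-fold lower number from compound 1 to compound 3 (0.14 log units; within the scatter). For the compounds shown here, this is the first direct reading at this position. Going by these compounds alone, until now no two measured compounds differed in this one place. It shows that this single added carbon leaves the cytotoxicity reading within the normal noise of repeat measurements. Within the data shown here, nothing measured so far gives a cause for this small step.

A much longer chain at this position, or a chain ending in an amine or a carboxylic acid, could still move the number well beyond that noise. A single step also cannot show whether the same methyl would behave alike on other compounds built on the shared core.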